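Cyclohexyl for octyl at the diene carbon

The compounds below may be only part of what the source reports. "The series", "measured", "known", "first", "only" and "open" are said of these compounds alone.

Measured:
compound 1, `CC[C@H](CCCc1cccnc1)NC(=O)/C=C/C=C(c1ccc(OC)cc1)c1ccc(OC)cc1`: 6 mg/kg
compound 2, `CCCCCCCC/C(=C\C=C\C(=O)N[C@H](C)CCCc1cccnc1)c1ccc(OC)cc1`: 13 mg/kg

Both were tested in a functional assay on the whole organism for inhibition, with Cavia porcellus as the target, with a stated time of 2 h; a higher number here means that more compound is needed for the effect, a lower number that less compound is needed. Of the two numbers compound 2 gives the higher; compound 1 gives a lower number, and the gap between them lies beyond the scatter. The two compounds differ in more than one place, so no single step can be read from them.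

Compound 3, `COc1ccc(/C(=C/C=C/C(=O)N[C@H](C)CCCc2cccnc2)C2CCCCC2)cc1`, is not yet measured. It keeps the whole of compound 2 except for one change, (cyclohexyl in place of octyl on a double-bonded chain carbon bound to an aromatic carbon and a double-bonded chain carbon). For the measured compounds named here, no measured pair shows a change of this kind, so the size of the step is not anchored by anything here. A small step is expected, if any, toward a lower number, with a spread wide enough to cover either direction. For compound 3 the estimate in this assay is 10 mg/kg, within 4 mg/kg to 25 mg/kg, which would be a step of a 1.3-fold lower number from compound 2 to compound 3 (0.11 log units; within the scatter).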

Compound 3, dose for 50% inhibition: 10 mg/kg
Compound 3: middle estimate and measured number agree at the digits printed; the range from low to high includes it.
By their numbers in this assay, from the lowest: compounds 1, 3 and 2 (each within the scatter of the next, the first and the last beyond it).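

In this assay, the series now has its first step that can be read at a single place: cyclohexyl in place of octyl gives a 1.3-fold lower number from compound 2 to compound 3 (0.11 log units; within the scatter) and so stays within the scatter. On a double-bonded chain carbon bound to an aromatic carbon and a double-bonded chain carbon, the open eight-carbon chain can therefore give way to a six-membered non-aromatic ring of carbon only without a step beyond the scatter. Nothing here accounts for the two groups reading alike.

Open at this position are a shorter chain such as butyl, a phenyl ring, and a chain ending in an amine or a carboxylic acid. This single pair also leaves open whether the exchange would read the same on any core other than that of compound 2.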